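The source may report more compounds than this note shows. Statements on the series, on what has been measured and on what is new or still open speak of the compounds shown alone.

Measured compounds in a functional assay on HeLa cells (Homo sapiens) for inhibition, read by MTT assay; a higher number here means a weaker inhibitor, a lower number a stronger inhibitor:
compound 1 `CCCCCCCCn1cc(/C=C/C(=O)c2ccc(NC(=O)CN3CCN(c4ccccc4F)CC3)cc2)nn1`: 33800 nM
compound 2 `CCCCCCCCn1cc(/C=C/C(=O)c2ccc(NC(=O)CN3CCN(c4ccccc4OC)CC3)cc2)nn1`: 26800 nM

In this assay compound 2 shows the lower of the two numbers, but the step of a 1.3-fold lower number from compound 1 to compound 2 (0.10 log units; within the scatter) lies within the scatter, so neither compound can be ranked above the other. Compound 3 `CCCCCCCCCCn1cc(/C=C/C(=O)c2ccc(NC(=O)CN3CCN(c4ccccc4OC)CC3)cc2)nn1` differs from compound 2 by ethyl in place of hydrogen on a saturated chain carbon, eight bonds along the chain from an aromatic nitrogen. For the measured compounds named here, the single measured step concerns the aryl substituent, not the chain, and was within the scatter; nothing measured bears directly on lengthening the chain. The expected step for compound 3 is therefore a 1.1-fold lower number from compound 2 to compound 3 (0.03 log units; within the scatter), none beyond the scatter. Compound 3 is estimated at 25000 nM, with a range from 8000 nM to 80000 nM.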

Compound 3, half-maximal inhibitory concentration: 50800 nM
Compound 3: middle estimate off by 2.0-fold (0.31 log units), on the low side; the range from low to high includes it.
By their numbers in this assay, from the lowest: compounds 2, 1 and 3 (each within the scatter of the next).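

In this assay the chain now has a step of its own, a 1.9-fold higher number from compound 2 to compound 3 (0.28 log units; within the scatter), so ethyl in place of hydrogen at this carbon, eight bonds along the chain from an aromatic nitrogen, cannot be read as changing the number. Earlier, only the aryl substituent had been compared, and this single pair sets no trend for the chain. Nothing available bears on this result.

From the compounds shown here alone, whether a longer chain, or an amine or a carboxylic acid in place of ethyl at this carbon, would give a step beyond the scatter remains open. Also open, going by these compounds, is whether the same ethyl change would give a similar step with fluoro on the aromatic carbon.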